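The source may report more compounds than this note shows. Statements on the series, on what has been measured and on what is new or still open speak of the compounds shown alone.

Series notes, cytotoxicity in a functional assay on A549 cells (Homo sapiens) for cytotoxicity, read by MTT assay, with a stated time of 72 h; a higher number here means a weaker inhibitor, a lower number a stronger inhibitor:

- compound 1 `CNC(=O)c1cc(Oc2ccc(C3=NNC(c4ccc(Cl)cc4Cl)C3)cc2)ccn1`: 6930 nM
- compound 2 `CNC(=O)c1cc(Oc2ccc(C3=NNC(c4ccc(F)cc4)C3)cc2)ccn1`: 15100 nM
- compound 3 `CNC(=O)c1cc(Oc2ccc(C3=NNC(c4ccc(Br)cc4)C3)cc2)ccn1`: 21000 nM

Compound 1 has the lowest number of the three in this assay. The step of a 2.2-fold higher number from compound 1 to compound 2 (0.34 log units; beyond the scatter) and the step of a 3.0-fold higher number from compound 1 to compound 3 (0.48 log units; beyond the scatter) are both modest and both beyond the scatter. Between compound 2 and compound 3 the step of a 1.4-fold higher number from compound 2 to compound 3 (0.14 log units; within the scatter) is within the scatter.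

Compound 4 `CNC(=O)c1cc(Oc2ccc(C3=NNC(c4cccc(Cl)c4Cl)C3)cc2)ccn1` is not yet measured. It differs from compound 1 as follows: 2,3-dichlorophenyl in place of 2,4-dichlorophenyl on a saturated ring carbon.

For the measured compounds named here, no measured step exchanges one dichlorophenyl for another, so nothing here bears on it directly. What the measured steps show is that any departure from the 2,4-dichlorophenyl of compound 1 toward a monohalophenyl, as in compound 2 and compound 3, raises the number modestly. The change to 2,3-dichlorophenyl keeps both chlorines and is smaller than those changes; the expected step of a 1.4-fold higher number from compound 1 to compound 4 (0.14 log units; within the scatter) is therefore at most modest, in the direction of a higher number, and may fall within the scatter. Compound 4 is estimated at 9500 nM in this assay, with a range from 4000 nM to 25000 nM.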

Compound 4, half-maximal inhibitory concentration: 12100 nM
Compound 4: the middle estimate sits 1.3-fold (0.11 log units) below what was measured; measured number inside the range.
By their numbers in this assay, from the lowest: compounds 1, 4, 2 and 3 (each within the scatter of the next, the first and the last beyond it).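

Working from this assay, the exchange of 2,4-dichlorophenyl for 2,3-dichlorophenyl on the saturated ring carbon gives the first comparison at this position in which the leaving and entering groups hold the same atoms, joined differently, and the result is a 1.7-fold higher number from compound 1 to compound 4 (0.24 log units; within the scatter). Compound 4 also does not separate from the monohalophenyl compounds, with a 1.2-fold lower number from compound 2 to compound 4 (0.10 log units; within the scatter) and a 1.7-fold lower number from compound 3 to compound 4 (0.24 log units; within the scatter), so keeping both chlorines does not by itself hold a number apart from theirs, even though compound 1 stands beyond the scatter from compound 2 and compound 3. Nothing available gives a cause for any of these steps.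

Still open, on these data alone, is how far this position tolerates groups other than halogens, such as a methoxy, an amine or a carboxylic acid on the phenyl, and how an unsubstituted phenyl or a 4-chlorophenyl would compare with compound 1. Also open, as far as these compounds go, is whether an acetyl on the ring nitrogen of the shared core would shift these numbers in this assay.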